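The source may report more compounds than this note shows. Statements on the series, on what has been measured and on what is new or still open speak of the compounds shown alone.

Working notes on the series. In a functional assay on PC-3 cells (Homo sapiens) for cytotoxicity, read by MTT assay, with a stated time of 48 h (on this read-out lower numbers stand for stronger inhibition and higher numbers for weaker inhibition), compound 1 `COc1ccc(-c2c(-c3cc(OC)c(OC)c(OC)c3)noc2N)cc1OC` gives 21100 nM, a measured number and the only one so far. Compound 2 `COc1cc(-c2noc(N)c2-c2ccc(Cl)cc2)cc(OC)c1OC` gives > 50000 nM in this assay, and this value is a limit of the assay, not a number. On these data alone, compound 2 therefore stands at the limit of > 50000 nM in this assay, at which 1 of the 2 values shown sits, and its true position on the scale remains unknown.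

The next compound is compound 3 `COc1cc(-c2noc(NC(C)=O)c2-c2ccc(Cl)cc2)cc(OC)c1OC`, which is built on the core of compound 2. The change is acetyl in place of hydrogen on a nitrogen on an aromatic ring, that is, amino to acetamido. Among the compounds with values here, no pair of measured compounds differs in one place, so no measured step gives a size for this change.

The expected change, an at least 1.1-fold lower number from compound 2 to compound 3 (0.04 log units; that floor lies within the scatter), is none beyond the scatter, with no firm direction. This expectation starts from compound 2 at > 50000 nM, and another reading reported only as a limit is quite possible.

For compound 3 the estimated value is 45000 nM, with an expected range from 18000 nM to 90000 nM.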

Compound 3, half-maximal inhibitory concentration: 1910 nM
The estimate for compound 3 lay 24-fold (1.37 log units) above the measured number; the whole stated range lies above it.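

In this assay, within the data shown here, acetyl in place of hydrogen on a nitrogen on an aromatic ring, that is, amino to acetamido, gives an at least 26-fold lower number from compound 2 to compound 3 (1.41 log units; beyond the scatter) as the first step of readable size. This position on the core of compound 2 therefore responds to a change on the nitrogen, and compound 3 gives 1910 nM as a measured number on this scale. The step is a floor and not a full size because its starting point, compound 2, is held at a limit of the assay: the limit of > 50000 nM in this assay, at which 1 of the 3 values shown sits.

With acetyl as the only group shown on this nitrogen, it stays open whether the carbonyl is needed or whether a plain alkyl group such as methyl, a longer acyl chain such as butanoyl, or a sulfonamide would give a comparable step. On these data alone, it also stays open whether amino to acetamido gives a step of similar size on the core of compound 1, and how much of the result depends on the rest of the core of compound 2.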